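Anilino variation on the shared core: toward compound 4

This account rests on a few compounds, and the source may have more. Where it says the series, first, only, none or still open, it means among the compounds named here.

Measured so far in a functional assay on MGC-803 cells (Homo sapiens) for inhibition, read by MTT assay, with a stated time of 72 h; on this read-out higher numbers stand for weaker inhibition and lower numbers for stronger inhibition:
compound 1, `C=CC(=O)Nc1cccc(NC(=O)CSc2nc(Nc3ccccc3Cl)c3ccccc3n2)c1`: 20700 nM
compound 2, `C=CC(=O)Nc1cccc(NC(=O)CSc2nc(Nc3ccccc3C)c3ccccc3n2)c1`: 30200 nM
compound 3, `C=CC(=O)Nc1cccc(NC(=O)CSc2nc(Nc3cccc(C)c3)c3ccccc3n2)c1`: 20900 nM

Compound 3 sits second highest of the three numbers; the gaps to compound 1 and compound 2 both stay within the scatter, as do the steps of a 1.0-fold higher number from compound 1 to compound 3 (0.00 log units; within the scatter) and a 1.4-fold lower number from compound 2 to compound 3 (0.16 log units; within the scatter). Compound 4, `C=CC(=O)Nc1cccc(NC(=O)CSc2nc(Nc3ccc(Br)cc3)c3ccccc3n2)c1`, differs from compound 3 by 4-bromophenyl in place of 3-methylphenyl on a nitrogen on an aromatic ring. Among the measured compounds shown here, no measured step bears directly on a bromo group or on this arrangement; the steps of a 1.5-fold higher number from compound 1 to compound 2 (0.16 log units; within the scatter), a 1.0-fold higher number from compound 1 to compound 3 (0.00 log units; within the scatter) and a 1.4-fold lower number from compound 2 to compound 3 (0.16 log units; within the scatter) only show that exchanging these anilino groups left this assay within the scatter each time. On that basis no step beyond the scatter is expected: a 1.1-fold higher number from compound 3 to compound 4 (0.02 log units; within the scatter). Compound 4 is estimated at 22000 nM, with a range of 9000 nM to 55000 nM.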

Compound 4, half-maximal inhibitory concentration: 11500 nM
Compound 4: middle estimate off by 1.9-fold (0.28 log units), on the high side; the measured number falls inside the stated range.
By their numbers in this assay, from the lowest: compounds 4, 1, 3 and 2 (each within the scatter of the next, the first and the last beyond it).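

Among the compounds shown here, exchanging the anilino group at this position now gives a step beyond the scatter for the first time: a 2.6-fold lower number from compound 2 to compound 4 (0.42 log units; beyond the scatter), with 4-bromophenyl in place of 2-methylphenyl. The steps of a 1.8-fold lower number from compound 3 to compound 4 (0.26 log units; within the scatter) and a 1.8-fold lower number from compound 1 to compound 4 (0.26 log units; within the scatter) stay within it, so compound 4 separates only from compound 2. No measured evidence accounts for this difference.

As far as these compounds go, it remains open whether this step follows the bromo group itself or its place on the phenyl ring. Also open, from the compounds shown here alone, is how an amine or a carboxylic acid on that ring would read in this assay.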